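The source may hold more compounds than are shown below. What is called first, only, known or untested is meant among the compounds shown, and "the series" means these compounds.

Working notes on the series. Three compounds share one core and differ only at one aromatic carbon. Compound 1 `Cc1ccc(-c2c[nH]cn2)cc1NC(=O)c1ccc(OCc2ccccn2)cc1` gives 90000 nM in a physicochemical assay for solubility, at pH 7.4; a higher number here means a more soluble compound, a lower number a less soluble compound. Compound 2 `Cc1ccc(-c2nccn2C)cc1NC(=O)c1ccc(OCc2ccccn2)cc1` gives 190000 nM in this assay. Compound 3 `Cc1ccc(-c2c(C)nn(C)c2C)cc1NC(=O)c1ccc(OCc2ccccn2)cc1` gives 5000 nM in this assay, the lowest of the three numbers: the step of an 18-fold lower number from compound 1 to compound 3 (1.26 log units; beyond the scatter) and the step of a 38-fold lower number from compound 2 to compound 3 (1.58 log units; beyond the scatter) both run beyond the scatter, whereas the step of a 2.1-fold higher number from compound 1 to compound 2 (0.32 log units; beyond the scatter) is modest.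

Compound 4 `Cc1ccc(-c2nccs2)cc1NC(=O)c1ccc(OCc2ccccn2)cc1` is not yet measured. Its change from compound 3 is 1,3-thiazol-2-yl in place of 1,3,5-trimethyl-1H-pyrazol-4-yl on an aromatic carbon. Within the data shown here, the steps that bear on it are the two into compound 3, an 18-fold lower number from compound 1 to compound 3 (1.26 log units; beyond the scatter) and a 38-fold lower number from compound 2 to compound 3 (1.58 log units; beyond the scatter), both large, and the change here runs the other way: compound 4 carries a ring without the methyl groups of the 1,3,5-trimethyl-1H-pyrazol-4-yl group, as compound 1 and compound 2 do. A large upward step is therefore expected: a 12-fold higher number from compound 3 to compound 4 (1.08 log units; beyond the scatter). Compound 4 is expected to give 60000 nM in this assay, with a range from 15000 nM to 200000 nM.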

Compound 4, solubility: < 1000 nM
Compound 4: a limit, no number (the forecaster's own chance of this, stated with the estimate: 5%); at least 60-fold (1.77 log units) between middle value and limit.
By their numbers in this assay, from the lowest: compound 3; then compound 1; then compound 2. At a limit, below all of these: compound 4.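

Exchanging 1,3,5-trimethyl-1H-pyrazol-4-yl for 1,3-thiazol-2-yl on this aromatic carbon gives an at least 5.0-fold lower number from compound 3 to compound 4 (0.69 log units; beyond the scatter), so a ring without methyl groups does not by itself raise the number at this position. The two other steps are large, an at least 190-fold lower number from compound 2 to compound 4 (2.27 log units; beyond the scatter) and an at least 90-fold lower number from compound 1 to compound 4 (1.95 log units; beyond the scatter), and the four compounds do not order by methyl groups: compound 2 carries one and has the highest number, while compound 4 carries none and sits lowest. In this assay compound 4 stands at a limit of the assay and not at a number: the limit of < 1000 nM in this assay, at which 1 of the 4 values shown sits.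

On these data alone, how far compound 4 lies under that limit remains open, so all three steps are bounds only. Also open, as far as these compounds go, is how a thiazole ring carrying a methyl group, or an amine or a carboxylic acid on the ring at this carbon, would read in this assay.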